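A few compounds are considered here, and "the series" means these few. Any claim that something is new, unique, unknown or untested is made for them only; others in the source may bear on it.

Measured so far in a functional assay on KB-V1 cells (Homo sapiens) for cytotoxicity, read by MTT assay, with a stated time of 72 h; a higher number here means a weaker inhibitor, a lower number a stronger inhibitor:

Compound 1 `COc1cc(NC(=S)N/N=C2\C(=O)Nc3ccccc32)cc(OC)c1OC`: 3490 nM
Compound 2 `CN(C)c1ccc(NC(=S)N/N=C2\C(=O)Nc3ccccc32)cc1`: 2320 nM

Compound 2, at 2320 nM, lies within the usual scatter of compound 1, at 3490 nM, so these two results cannot be ranked. The next compound to consider is compound 3 `CCc1ccc(NC(=S)N/N=C2\C(=O)Nc3ccccc32)cc1`. It keeps the shared core of compound 2 but carries ethyl in place of dimethylamino on an aromatic carbon, para to a large group (ethyl in place of dimethylamino on an aromatic carbon).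

Within the data shown here, no measured pair here differs in one place only, so the data offer no direct guide to the size of this step. The only clue is indirect: compound 1 and compound 2 have different groups on their aromatic rings, yet compound 2 at 2320 nM remains within the scatter of compound 1. On that limited evidence, no change beyond the scatter is expected in this assay, and no clear direction can be predicted. The estimated change is a 1.1-fold higher number from compound 2 to compound 3 (0.03 log units; within the scatter). For compound 3, the expected value is 2500 nM, with an estimated range from 900 nM to 7000 nM.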

Compound 3, half-maximal inhibitory concentration: 1340 nM
Estimate against measurement, compound 3: 1.9-fold (0.27 log units) above, within the range that was stated.
By their numbers in this assay, from the lowest: compounds 3, 2 and 1 (each within the scatter of the next, the first and the last beyond it).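

Among these compounds, this is the first step that changes one place only, so it gives a first direct reading of this position in this assay: ethyl in place of dimethylamino on an aromatic carbon, para to a large group, gives a 1.7-fold lower number from compound 2 to compound 3 (0.24 log units; within the scatter) in this pair. The group that leaves holds a nitrogen and a hydrogen-bond acceptor and the group that enters holds neither, yet compound 2 and compound 3 cannot be ranked, so in this one pair that difference does not show up beyond the usual scatter. Nothing measured here accounts for the size of this step or describes the properties of either group.

The compounds shown leave open whether another kind of group at this position, such as a carboxylic acid, a primary amine or a longer alkyl chain, would give a step beyond the scatter. One pair also cannot show whether the same exchange would give a similar step on a ring that carries further groups.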